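The compounds below may be only part of what the source reports. "The series", "measured", "known", "first", "only" and "open" are said of these compounds alone.

Compounds measured in a functional assay on NCI-H661 cells (Homo sapiens) for cytotoxicity, read by WST assay, with a stated time of 72 h; on this read-out higher numbers stand for weaker inhibition and lower numbers for stronger inhibition:
compound 1 `COc1cc2c(Nc3nc4ccc(C(=O)Nc5c(C)cc(C)cc5C)cc4s3)ncnc2cc1OCCCN1CCC(C)CC1` — 7700 nM
compound 2 `CCN(CC)CCCOc1cc2ncnc(Nc3nc4ccc(C(=O)Nc5c(C)cc(C)cc5C)cc4s3)c2cc1OC` — 7300 nM
compound 3 `COc1cc2c(Nc3nc4ccc(C(=O)Nc5c(C)cc(C)cc5C)cc4s3)ncnc2cc1OCCCN1CCCCC1` — 10000 nM

Compound 3 carries the highest of the three numbers, but its gap to compound 1 and its gap to compound 2 are both within the scatter, so the three read as one level.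

Compound 4 `COc1cc2c(Nc3nc4ccc(C(=O)Nc5c(C)cc(C)cc5C)cc4s3)ncnc2cc1OCCCN1CCCC1` differs from compound 3 only at the chain end: pyrrolidin-1-yl in place of piperidin-1-yl on a saturated chain carbon, three bonds along the chain from an oxygen on an aromatic ring.

For the measured compounds named here, the steps that bear on this change are those that alter the same terminal amine. The step of a 1.4-fold higher number from compound 2 to compound 3 (0.14 log units; within the scatter) exchanged an open-chain amine for a ring amine at this position, and the step of a 1.3-fold higher number from compound 1 to compound 3 (0.11 log units; within the scatter) removed a methyl from that ring; the step of a 1.1-fold lower number from compound 1 to compound 2 (0.02 log units; within the scatter) likewise left the number where it was. Every variation of the amine end in this set has stayed within the scatter. Shrinking the ring by one carbon is therefore expected to give no step beyond the scatter, a 1.1-fold lower number from compound 3 to compound 4 (0.05 log units; within the scatter).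

Compound 4 is estimated at 9000 nM in this assay, with a range from 4500 nM to 18000 nM.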

Compound 4, half-maximal inhibitory concentration: 9600 nM
Compound 4: the middle estimate sits 1.1-fold (0.03 log units) below what was measured; the measured number falls inside the stated range.
By their numbers in this assay, from the lowest: compounds 2, 1, 4 and 3 (each within the scatter of the next).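

In this assay, for the compounds shown here, the size of the ring at the chain end varies here for the first time, and pyrrolidin-1-yl in place of piperidin-1-yl gives a 1.0-fold lower number from compound 3 to compound 4 (0.02 log units; within the scatter), so the five-membered and six-membered rings read as one level. The new ring also stays level with the other two amine ends, with a 1.3-fold higher number from compound 2 to compound 4 (0.12 log units; within the scatter) and a 1.2-fold higher number from compound 1 to compound 4 (0.10 log units; within the scatter). At this place on the 3-(pyrrolidin-1-yl)propyl side chain and its counterparts, diethylamino, 4-methylpiperidin-1-yl, piperidin-1-yl and pyrrolidin-1-yl are therefore not told apart, and no measurement at hand offers an explanation for this flat response.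

From the compounds shown here alone, whether a morpholine, a piperazine or a carboxylic acid at the chain end would hold this level remains open. So does the effect of a shorter ethyl chain or a longer butyl chain carrying the same amines.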